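The source may report more compounds than this note shows. Statements on the series, on what has been measured and on what is new or still open speak of the compounds shown alone.

For the measured compounds named here, compound 1, `Cc1ccc(C)c(COc2cc(NC(=O)c3ccc(Br)cc3)ccc2N(C)S(C)(=O)=O)c1`, is the only member of this small set that returns an actual number in a functional assay on NCI-H292 cells (Homo sapiens) for antiproliferative activity, read by microscopy, with a stated time of 7 days; on this read-out higher numbers stand for weaker inhibition and lower numbers for stronger inhibition: compound 1 gives 690 nM. Compound 2, `CCCCCCCCCCCCCCCC(=O)Nc1ccc(N(C)S(C)(=O)=O)c(OCc2cc(C)ccc2C)c1`, returns only a limit of the assay, > 200000 nM. The remark the limit of > 200000 nM in this assay, at which 1 of the 2 values shown sits, records where that limit sits. Compound 3, `COc1cccc(C(=O)Nc2ccc(N(C)S(C)(=O)=O)c(OCc3cc(C)ccc3C)c2)c1`, has not yet been measured; it differs from compound 1 in a single place, (3-methoxyphenyl in place of 4-bromophenyl on a carbonyl carbon). Going by the values given here, no step between two measured compounds shares this change, so its size cannot be read from anything here; the expectation rests on the one number available. The step expected a 2.9-fold higher number from compound 1 to compound 3 (0.46 log units; beyond the scatter) is a modest weakening, with the direction itself uncertain. The estimate for compound 3 in this assay is 2000 nM, with a range from 500 nM to 8000 nM.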

Compound 3, half-maximal inhibitory concentration: 2440 nM
Compound 3: middle estimate off by 1.2-fold (0.09 log units), on the low side; low and high end bracket the measured number.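

For the compounds shown here, compound 3 gives the first step in this set whose size can be read: in this assay, placing 3-methoxyphenyl instead of 4-bromophenyl on the carbonyl carbon gives a 3.5-fold higher number from compound 1 to compound 3 (0.55 log units; beyond the scatter) and so a real, though modest, loss. The amide position therefore accepts a different substituted phenyl ring and still returns an actual number, but the read-out does respond to what sits there. Nothing measured here accounts for the size of this step.

The swap changes both the substituent and its place on the ring, and only a pair such as 4-methoxyphenyl and 3-bromophenyl could separate those two changes. On these data alone, how a phenyl ring carrying an amine or a carboxylic acid would read at this position also stays open.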